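The compounds below may be only part of what the source reports. "The series", "measured", "known", "first", "only" and "open" are said of these compounds alone.

Measured in a functional assay on MT4 cells (Homo sapiens); a higher number here means that more compound is tolerated, a lower number that less compound is tolerated:
- compound 1 `CC(=O)NC1=CS(=O)(=O)O[C@@]12[C@@H](CO[Si](C)(C)C(C)(C)C)O[C@@H](n1cc(C)c(=O)n(C)c1=O)[C@@H]2O[Si](C)(C)C(C)(C)C`: 10700 nM
- compound 2 `COC(=O)CC(=O)NC1=CS(=O)(=O)O[C@@]12[C@@H](CO[Si](C)(C)C(C)(C)C)O[C@@H](n1cc(C)c(=O)n(C)c1=O)[C@@H]2O[Si](C)(C)C(C)(C)C`: 11900 nM
- compound 3 `Cc1cn([C@@H]2O[C@H](CO[Si](C)(C)C(C)(C)C)[C@@]3(OS(=O)(=O)C=C3NC(=O)c3ccccc3)[C@H]2O[Si](C)(C)C(C)(C)C)c(=O)n(C)c1=O`: 4900 nM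

Compound 3 holds the lowest number of the three. The gaps to it are modest: a 2.2-fold lower number from compound 1 to compound 3 (0.34 log units; beyond the scatter) and a 2.4-fold lower number from compound 2 to compound 3 (0.39 log units; beyond the scatter). Compounds 1 and 2 stand together, with a 1.1-fold higher number from compound 1 to compound 2 (0.05 log units; within the scatter).

The next compound is compound 4 `Cc1cn([C@@H]2O[C@H](CO[Si](C)(C)C(C)(C)C)[C@@]3(OS(=O)(=O)C=C3NCC(=O)C(N)=O)[C@H]2O[Si](C)(C)C(C)(C)C)c(=O)n(C)c1=O`, with the change ((carbamoylcarbonyl)methyl in place of benzoyl on an amine nitrogen). The phenyl of compound 3 is gone, and no ring enters in its place. The two steps to compound 3 therefore bear on this change when read backwards, although the evidence is indirect: all three measured compounds carry a carbonyl on that nitrogen, and compound 4 does not. For the measured compounds named here, since a 2.2-fold lower number from compound 1 to compound 3 (0.34 log units; beyond the scatter) and a 2.4-fold lower number from compound 2 to compound 3 (0.39 log units; beyond the scatter) are the only steps that involve the phenyl, a modest rise is expected, about the size of those steps: a 2.0-fold higher number from compound 3 to compound 4 (0.31 log units; beyond the scatter). The estimate for compound 4 is 10000 nM, with an expected range of 4500 nM to 25000 nM.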

Compound 4, half-maximal cytotoxic concentration: 9590 nM
Beside the measured number, compound 4's estimate is 1.0-fold (0.02 log units) above it, and the stated range covers the measured number.
By their numbers in this assay, from the lowest: compounds 3, 4, 1 and 2 (each within the scatter of the next, the first and the last beyond it).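

On the amine nitrogen, compound 4 is the only one of the series without a carbonyl on that nitrogen, yet its (carbamoylcarbonyl)methyl group keeps it within the scatter of all three earlier compounds in this assay (a 2.0-fold higher number from compound 3 to compound 4 (0.29 log units; within the scatter); a 1.2-fold lower number from compound 2 to compound 4 (0.09 log units; within the scatter); a 1.1-fold lower number from compound 1 to compound 4 (0.05 log units; within the scatter)). Removing that carbonyl therefore gives no separation from the acetyl or ((methoxycarbonyl)methyl)carbonyl groups, and compound 3, with benzoyl, does not stand apart from compound 4 as it does from compound 1 and compound 2. No accompanying measurement offers an explanation for these numbers.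

Still open, going by these compounds, is how a plain ethyl chain, a longer alkyl chain or a carboxylic acid at this nitrogen would read in this assay. A benzyl group would help separate the phenyl from the carbonyl of benzoyl.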